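Cytotoxicity limits in a biphenyl amide series

The source may report more compounds than this note shows. Statements on the series, on what has been measured and on what is new or still open speak of the compounds shown alone.

Measured so far:
- Compound 1 `CCOC(=O)CCCCCOc1cccc(CN(C(=O)c2ccc(-c3cccc4ccccc34)cc2)C(C)C)c1`, in an ADME assay on HEK293 cells (Homo sapiens) for cytotoxicity, read by CellTiter-Glo and resazurin assay, with a stated time of 72 h (a higher number here means that more compound is needed for the effect, a lower number that less compound is needed), a limit only: > 26000 nM.
- Compound 2 `CCOC(=O)CCCCCOc1cccc(CN(C(=O)c2ccc(-c3cccc(C(C)=O)c3)cc2)C(C)C)c1`, in this assay likewise a limit: > 26000 nM.

Compound 2 thus stands at the limit of > 26000 nM in this assay, at which 2 of the 2 values shown sit, with no number to place it. Going by the values given here, the one step in this assay, a step that the two limits leave unreadable from compound 1 to compound 2, is unreadable for the same reason. Compound 3 `CCOC(=O)CCCCCOc1cccc(CN(C(=O)c2ccc(-c3cccc(OCC(C)C)c3)cc2)C(C)C)c1` differs from compound 2 by isobutoxy in place of acetyl on an aromatic carbon. Among the compounds with values here, with both neighbours at the limit, no measured step bears on this change. The step that the limit leaves unreadable from compound 2 to compound 3 is expected to be none beyond the scatter. Compound 3 is estimated at 45000 nM, between 20000 nM and 120000 nM, most likely reported again as a limit.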

Compound 3, half-maximal effective concentration: > 26000 nM
Compound 3: a limit, no number; the forecaster's own chance of this, stated with the estimate: 85%; the middle value is on the limit's open side.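

In this assay compound 3 gives only a limit, > 26000 nM. Going by these compounds alone, no step among compound 1, compound 2 and compound 3 can be read. Going by these compounds, it remains open whether these three compounds differ at all, and at what concentration any of them shows the effect.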